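The source may hold more compounds than are shown below. What is called first, only, known or untested is meant among the compounds shown, and "the series" means these compounds.

Measured so far in a functional assay on HeLa cells (Homo sapiens) for cytotoxicity, read by MTT assay, with a stated time of 48 h; on this read-out lower numbers stand for stronger inhibition and higher numbers for weaker inhibition:

Compound 1, `Cc1ccc(Cn2c(/C=C3\SC(=S)N(CC(=O)O)C3=O)nc3ccc(F)cc32)cc1`: 3920 nM
Compound 2, `COc1ccc2nc(/C=C3\SC(=S)N(CC(=O)O)C3=O)n(Cc3ccc(C)cc3)c2c1`: 6440 nM
Compound 3, `O=C(O)CN1C(=O)/C(=C/c2nc3cc(F)ccc3n2Cc2ccccc2F)SC1=S`: reported only as the limit > 50000 nM

Compound 1 and compound 2 share one core and differ in a single place, (methoxy in place of fluoro on an aromatic carbon). In this assay the step is a 1.6-fold higher number from compound 1 to compound 2 (0.22 log units; within the scatter), so the two values cannot be told apart. Compound 3 carries the second core, and in this assay compound 3 is not given as a number but as the limit > 50000 nM. the limit of > 50000 nM in this assay, at which 1 of the 3 values shown sits. The difference between the core of compound 1 and the core of compound 3 is not broken down here.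

Compound 4, `COc1ccc2c(c1)nc(/C=C1\SC(=S)N(CC(=O)O)C1=O)n2Cc1ccccc1F`, is not yet measured. It differs from compound 3 by the same change that turns compound 1 into compound 2: methoxy in place of fluoro on an aromatic carbon. The place of the change is described in identical words for both pairs, so it is the same change made on the second core.

Going by the values given here, the expectation for this assay rests on the one measured example of the change, the step of a 1.6-fold higher number from compound 1 to compound 2 (0.22 log units; within the scatter). With compound 3 already at the limit, the step from compound 3 to compound 4 is expected to be about a step that the limit leaves unreadable from compound 3 to compound 4. Compound 4 is therefore estimated at about 80000 nM, most plausibly between 40000 nM and 200000 nM, and the assay is expected to report again only a limit rather than a number.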

Compound 4, half-maximal inhibitory concentration: 22500 nM
Beside the measured number, compound 4's estimate is 3.6-fold (0.55 log units) above it; the measured number lies below the stated range.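

In this assay, methoxy in place of fluoro on an aromatic carbon does not carry over from the core of compound 1 to the core of compound 3 with one and the same effect: the same change on two cores in this assay, a 1.6-fold higher number (0.22 log units; within the scatter) from compound 1 to compound 2 and an at least 2.2-fold lower number (0.34 log units; beyond the scatter) from compound 3 to compound 4, at least 3.6-fold (0.56 log units) apart, beyond the scatter of two such steps

On the core of compound 3, the change gives an at least 2.2-fold lower number from compound 3 to compound 4 (0.34 log units; beyond the scatter), so on this core the methoxy compound reads lower, whereas on the core of compound 1 the two values cannot be told apart. From the compounds shown here alone, compound 3 is reported only as a limit, > 50000 nM; the full size of its step therefore stays unknown, and with one pair on each core the result shows a difference between these two pairs, not a rule for other cores.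

Open, going by these compounds, is whether other groups on the same aromatic carbon, such as chloro, hydroxy or an amine, would also separate the two cores in this way. Also open, on these data alone, is whether the difference between the cores would persist with a longer chain in place of the acetic acid side chain, or with an amide in place of the carboxylic acid.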